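A few compounds are considered here, and "the series" means these few. Any claim that something is new, unique, unknown or untested is made for them only; others in the source may bear on it.

Compound 3 `CCCc1nc(-c2ccccc2)c(CNCCCN2CCN(c3ccccc3)CC2)o1` carries a plain phenyl on the amine nitrogen in a ring of the shared core. For the measured compounds named here, in an assay on HEK293 cells for inhibition of Voltage-dependent T-type calcium channel subunit alpha-1G (Homo sapiens), read by fluorescence, tested at 10 uM (on this read-out lower numbers stand for less inhibition and higher numbers for more inhibition at the one concentration tested (going by the name of the read-out)), compound 3 gives 43.7%, the lowest of the three numbers measured so far. Its nearest neighbour is compound 1 `CCCc1nc(-c2ccccc2)c(CNCCCN2CCN(c3cccc(C(F)(F)F)c3)CC2)o1`, which in this assay gives 51.6%; the step of a number 7.9 percentage points lower from compound 1 to compound 3 (within the scatter), so these two compounds cannot be told apart. The furthest is compound 2 `CCCc1nc(-c2ccccc2)c(CNCCN2CCN(C(c3ccccc3)c3ccccc3)CC2)o1`, which gives 71.9% and stands beyond the scatter above compound 3.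

Compound 4 `CCCc1nc(-c2ccccc2)c(CNCCCN2CCN(c3ccc(C)c(C)c3)CC2)o1` has not yet been measured. Its difference from compound 3 is 3,4-dimethylphenyl in place of phenyl on an amine nitrogen in a ring. Going by the values given here, the one measured step that bears on a change of the group on this ring nitrogen is a number 7.9 percentage points lower from compound 1 to compound 3 (within the scatter): swapping a substituent on that aromatic ring moved the inhibition by less than the scatter. Adding two methyl groups is therefore expected to give, at most, a small step, with no reliable direction, so the estimated step is a number 6.3 percentage points higher from compound 3 to compound 4 (within the scatter). Compound 4 is expected to give about 50%, within a range from 30% to 70%.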

Compound 4, a percentage reported as inhibition, at one concentration (the size of the read-out at that concentration, not a potency): 54.6%
Compound 4: middle estimate off by 4.6 percentage points, on the low side; the range from low to high includes it.
By their numbers in this assay, from the lowest: compounds 3, 1 and 4 (each within the scatter of the next, the first and the last beyond it); then compound 2.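

In this assay, for the compounds shown here, the 3,4-dimethylphenyl group gives a number 10.9 percentage points higher from compound 3 to compound 4 (beyond the scatter), a modest step but the only one on this ring nitrogen among compounds 1, 3 and 4 that lies beyond the scatter. So a substituted phenyl here can be told apart from plain phenyl, though only just. The two substituted rings cannot be told apart, with a number 3 percentage points higher from compound 1 to compound 4 (within the scatter), and nothing measured here explains the step to compound 4.

From the compounds shown here alone, it remains open whether a single methyl on the phenyl ring would be enough, or whether both methyl groups are needed for this step. Going by these compounds, how a methoxy group or a chlorine atom on that ring would compare with these two substituted rings also stays unknown.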